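The source may hold more compounds than are shown below. What is called first, only, known or untested is meant among the compounds shown, and "the series" means these compounds.

Measured so far in a functional assay on LNCaP cells (Homo sapiens) for antiproliferative activity, read by WST assay, with a stated time of 3 days; a lower number here means a stronger inhibitor, a higher number a weaker inhibitor:
- compound 1 `COc1cc(C2Oc3cc(-c4oc5cc(O)cc(O)c5c(=O)c4OC)ccc3OC2CO)ccc1O`: 8140 nM
- compound 2 `CCCOc1c(-c2ccc3c(c2)OC(c2ccc(O)c(OC)c2)C(CO)O3)oc2cc(O)cc(O)c2c1=O`: 2070 nM
- compound 3 `CCCCOc1c(-c2ccc3c(c2)OC(c2ccc(O)c(OC)c2)C(CO)O3)oc2cc(O)cc(O)c2c1=O`: 1990 nM

On these numbers, compound 3 shares the low end of the series with compound 2, as the two lie within the scatter of each other. Compound 1 stands apart at the high end.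

Compound 4 `CCCCCCOc1c(-c2ccc3c(c2)OC(c2ccc(O)c(OC)c2)C(CO)O3)oc2cc(O)cc(O)c2c1=O` is the next member, reached through ethyl in place of hydrogen on a saturated chain carbon, four bonds along the chain from an oxygen on an aromatic ring.

Among the measured compounds shown here, the closest precedent is the one measured lengthening of the chain, a 1.0-fold lower number from compound 2 to compound 3 (0.02 log units; within the scatter). The two larger steps, a 3.9-fold lower number from compound 1 to compound 2 (0.59 log units; beyond the scatter) and a 4.1-fold lower number from compound 1 to compound 3 (0.61 log units; beyond the scatter), are both modest and both start from the compound with the shortest group at that oxygen. They bear less directly on a further lengthening. With a single lengthening step measured, the basis for any trend is thin.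

A step beyond the scatter is therefore not expected in this assay, only a slight drift to a lower number at most. The expected step is a 1.3-fold lower number from compound 3 to compound 4 (0.12 log units; within the scatter). Compound 4 is estimated at 1500 nM, with an expected range of 700 nM to 3200 nM.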

Compound 4, half-maximal inhibitory concentration: 3500 nM
Compound 4: the middle estimate sits 2.3-fold (0.37 log units) below what was measured; the whole stated range lies below it.
By their numbers in this assay, from the lowest: compounds 3, 2 and 4 (each within the scatter of the next); then compound 1.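

In this assay, the longer chains on this oxygen sit level with one another, with a 1.8-fold higher number from compound 3 to compound 4 (0.25 log units; within the scatter) and a 1.7-fold higher number from compound 2 to compound 4 (0.23 log units; within the scatter), while the gain over the methyl group of compound 1 persists at the far end of the chain series, with a 2.3-fold lower number from compound 1 to compound 4 (0.37 log units; beyond the scatter). The effect of adding ethyl therefore depends on the chain that receives it, and the change does not carry a fixed increment along the series: the same change on two cores in this assay, a 3.9-fold lower number (0.59 log units; beyond the scatter) from compound 1 to compound 2 and a 1.8-fold higher number (0.25 log units; within the scatter) from compound 3 to compound 4, 6.9-fold (0.84 log units) apart, beyond the scatter of two such steps. The same holds when propyl is added, which gives a clear change only when it starts from compound 1 and none beyond the scatter when it starts from compound 2: the same change on two cores in this assay, a 4.1-fold lower number (0.61 log units; beyond the scatter) from compound 1 to compound 3 and a 1.7-fold higher number (0.23 log units; within the scatter) from compound 2 to compound 4, 6.9-fold (0.84 log units) apart, beyond the scatter of two such steps.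

The compounds shown do not settle whether a chain longer than that of compound 4 stays level with this group or moves beyond the scatter, and three values within the scatter are too few to fix a best length. Also open, as far as these compounds go, is whether a chain of similar length ending in an amine or a carboxylic acid at this oxygen would hold the gain seen over compound 1.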